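The compounds below may be only part of what the source reports. "The series", "measured", "known", "first", "only" and "open" are said of these compounds alone.

Of the compounds shown here, three have so far been measured in a functional assay on T47D cells (Homo sapiens) for cytotoxicity, read by sulforhodamine B assay, with a stated time of 72 h; a lower number here means a stronger inhibitor, a higher number a weaker inhibitor. Compound 1 `Cc1ccc(S(=O)(=O)n2cnc3c(Cl)ncnc32)cc1` gives 13900 nM in this assay. Compound 2 `FC(F)(F)c1ccc(N2CCN(c3ncnc4[nH]cnc34)CC2)cc1` gives 39400 nM in this assay. Compound 3 `Cc1ccc(S(=O)(=O)n2cnc3c(NCc4ccc(F)cc4F)ncnc32)cc1` gives 116000 nM in this assay. Of these three numbers, compound 2 stands second highest: its value lies between those of compound 1 and compound 3, and each of those two gaps is beyond the usual scatter of repeated measurements.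

The unmeasured compound 4 `FC(F)(F)c1ccc(N2CCN(c3ncnc4c3ncn4C3CCCC3)CC2)cc1` differs from compound 2 in a single place, (cyclopentyl in place of hydrogen on an aromatic nitrogen), in words cyclopentyl in place of hydrogen on an aromatic nitrogen. For the measured compounds named here, no pair of measured compounds shows this change, so there is no measured step to draw on and the expectation rests on the structural change alone. The expected step, a 2.6-fold lower number from compound 2 to compound 4 (0.42 log units; beyond the scatter), is a moderate move toward a lower number, slightly beyond the scatter, held with considerable uncertainty. Compound 4 is therefore estimated at 15000 nM in this assay. For compound 4 the lower end of that estimate is 4000 nM. For compound 4 the upper end of that estimate is expected to be 60000 nM.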

Compound 4, half-maximal inhibitory concentration: < 100 nM
Compound 4: no number, only a limit; the forecaster's own chance of this, stated with the estimate: 10%; at least 150-fold (2.17 log units) between middle value and limit.
By their numbers in this assay, from the lowest: compound 1; then compound 2; then compound 3. At a limit, below all of these: compound 4.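

In this assay, cyclopentyl in place of hydrogen on an aromatic nitrogen gives an at least 390-fold lower number from compound 2 to compound 4 (2.59 log units; beyond the scatter) and so shows that this one position on the core of compound 2 can carry a very large change in the number. For the compounds shown here, the earlier compounds could not show this, as no two of them differed in one place, and this is the first step in the set that can be read directly. Compound 4 has no exact number, only a limit: the limit of < 100 nM in this assay, at which 1 of the 4 values shown sits.

Going by these compounds, how far the step reaches past that limit remains open. On these data alone, it also remains open whether a methyl, a cyclohexyl, a longer carbon chain or a chain ending in an amine on the same nitrogen would give a step of similar size, so nothing yet ties the step to cyclopentyl itself.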